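This account rests on a few compounds, and the source may have more. Where it says the series, first, only, none or still open, it means among the compounds named here.

In an ADME assay on MT2 cells (Homo sapiens) for cytotoxicity, read by MTT assay (on this read-out lower numbers stand for higher toxicity in this test and higher numbers for lower toxicity in this test), compound 3 `COCc1ccc(Nc2nnc(Cc3c(Cl)cccc3Cl)o2)cc1` gives 100000 nM, the highest of the two numbers shown. Its nearest neighbour is compound 1 `Clc1cccc(Cl)c1Cc1nnc(Nc2ccc(COCc3ccoc3)cc2)o1`, which in this assay gives 21000 nM. Compound 2 `Clc1cccc(Cl)c1Cc1nnc(Nc2ccc(COCc3ccsc3)cc2)o1` gives in this assay > 100000 nM, which is a limit of the assay and not a number. The change from compound 3 to compound 4 `Clc1cccc(Cl)c1Cc1nnc(Nc2ccc(COCc3ccncc3)cc2)o1` is pyridin-4-yl in place of hydrogen on a saturated chain carbon bound to an oxygen on a saturated carbon. Within the data shown here, two measured steps bear on this change. The step of a 4.8-fold higher number from compound 1 to compound 3 (0.68 log units; beyond the scatter) shows that hydrogen in place of furan-3-yl at this place raised the number, so a ring entering at the same place is likely to lower it again. The step of a number no higher from compound 2 to compound 3 (the limit leaves the size open) leaves the size open because of the limit of > 100000 nM in this assay, at which 1 of the 3 values shown sits. The entering pyridin-4-yl is neither the furan nor the thiophene seen so far, so the expected change lies between no change beyond the scatter and a modest lowering. For compound 4 the estimate in this assay is therefore 50000 nM, within 15000 nM to 100000 nM. This estimate means an expected step of a 2.0-fold lower number from compound 3 to compound 4 (0.30 log units; within the scatter).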

Compound 4, half-maximal cytotoxic concentration: 81000 nM
Estimate against measurement, compound 4: 1.6-fold (0.21 log units) below; the measured number falls inside the stated range.
By their numbers in this assay, from the lowest: compound 1; then compounds 4 and 3 (each within the scatter of the next).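

In this assay, putting pyridin-4-yl on a saturated chain carbon bound to an oxygen on a saturated carbon leaves the number within the scatter: a 1.2-fold lower number from compound 3 to compound 4 (0.09 log units; within the scatter). A ring entering at this place therefore need not lower the number, and the lower number of compound 1 does not hold for every ring here, as the other readable step shows: a 3.9-fold higher number from compound 1 to compound 4 (0.59 log units; beyond the scatter). The remaining step, an at least 1.2-fold lower number from compound 2 to compound 4 (0.09 log units; that floor lies within the scatter), has no readable size because it rests on a limit: the limit of > 100000 nM in this assay, at which 1 of the 4 values shown sits.

From the compounds shown here alone, what sets furan-3-yl apart from the other two rings remains open, since these few compounds offer only a comparison of named groups. Going by these compounds, whether a plain phenyl ring, a pyridin-2-yl ring or a chain ending in an amine would behave like furan-3-yl or like pyridin-4-yl also remains unknown.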